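Propargyl benzimidazole hydrazones: exchanging the aryl terminus

This account rests on a few compounds, and the source may have more. Where it says the series, first, only, none or still open, it means among the compounds named here.

Compound 1, `C#CCn1c(-c2ccc(C(=O)N/N=C/c3ccc[nH]3)cc2)nc2ccccc21`, in an assay on cells for inhibition of Amine oxidase [flavin-containing] B (Homo sapiens), read by fluorescence and Amplex Red, with stated times of 30 min and 5 min (a lower number here means a stronger inhibitor, a higher number a weaker inhibitor), gives a value that is a limit of the assay, >= 1000000 nM.
Compound 2, `C#CCn1c(-c2ccc(C(=O)N/N=C/c3cccn3C)cc2)nc2ccccc21`, in this assay gives 12200 nM.

Compound 2 holds the only actual number shown; the other value is a limit. Going by the values given here, the single measured step, an at least 81-fold lower number from compound 1 to compound 2 (1.91 log units; beyond the scatter), rests on (the limit of >= 1000000 nM in this assay, at which 1 of the 2 values shown sits), so only its lower bound is known. Compound 3, `C#CCn1c(-c2ccc(C(=O)N/N=C/c3ccc(Cl)cc3)cc2)nc2ccccc21`, differs from compound 2 by 4-chlorophenyl in place of 1-methyl-1H-pyrrol-2-yl on a carbon with a double bond to nitrogen. The measured step concerns a methyl on an aromatic nitrogen and does not test an exchange of the whole ring, so it gives little guidance; compound 3, like compound 2, carries no hydrogen on an aromatic nitrogen at this place. Compound 3 is therefore expected to stay near compound 2, with a small improvement as the more likely direction, giving an expected step of a 2.4-fold lower number from compound 2 to compound 3 (0.39 log units; beyond the scatter). The estimate for compound 3 in this assay is 5000 nM, between 800 nM and 40000 nM.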

Compound 3, half-maximal inhibitory concentration: 10200 nM
Compound 3: middle estimate off by 2.0-fold (0.31 log units), on the low side; measured number inside the range.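

In this assay, a whole-ring exchange on a carbon with a double bond to nitrogen gives a 1.2-fold lower number from compound 2 to compound 3 (0.08 log units; within the scatter), so 1-methyl-1H-pyrrol-2-yl and 4-chlorophenyl are not told apart here, though one is a five-membered ring with a nitrogen and the other a six-membered ring of carbon only. Among the compounds shown, only compound 1 carries a hydrogen on an aromatic nitrogen at this place, and only compound 1 stands at a limit of the assay. Its comparison with the 4-chlorophenyl compound, an at least 98-fold lower number from compound 1 to compound 3 (1.99 log units; beyond the scatter), therefore gives a lower bound only: the limit of >= 1000000 nM in this assay, at which 1 of the 3 values shown sits.

The compounds shown leave open whether the chlorine contributes anything, which a plain phenyl would test. As far as these compounds go, it also remains open whether an amine or a carboxylic acid on this ring would shift the number in either direction.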